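The source may report more compounds than this note shows. Statements on the series, on what has been measured and on what is new or still open speak of the compounds shown alone.

- compound 1 `CC(C)(O)CCc1c(O)cc(O)c2c(=O)c(-c3ccc(O)cc3)coc12` gives 135000 nM
- compound 2 `CC(C)(O)CCc1c(O)cc(O)c2c(=O)c(-c3ccc(O)c(O)c3)coc12` gives 85900 nM

In a toxicity assay on HaCaT cells (Homo sapiens) for cytotoxicity, read by CellTiter-Blue, with a stated time of 24 h (on this read-out higher numbers stand for weaker inhibition and lower numbers for stronger inhibition), compound 2 stands at 85900 nM and lies within the scatter of compound 1, so the two numbers cannot be told apart. Compound 3 `COc1cc(-c2coc3c(CCC(C)(C)O)c(O)cc(O)c3c2=O)ccc1O` differs from compound 2 by a single change methyl in place of hydrogen on an oxygen on an aromatic ring in which 3,4-dihydroxyphenyl becomes 4-hydroxy-3-methoxyphenyl. Among the compounds with values here, no measured step shows this change directly. Within the data shown here, the only step available is a 1.6-fold lower number from compound 1 to compound 2 (0.20 log units; within the scatter) with hydroxy in place of hydrogen on an aromatic carbon, and it does not go beyond the scatter. On that slender evidence, no step beyond the scatter is expected in this assay for this methyl on an oxygen. The expected step is a 1.2-fold higher number from compound 2 to compound 3 (0.07 log units; within the scatter) and no more than that. Compound 3 is estimated at 100000 nM with an expected range from 50000 nM to 200000 nM as its upper end.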

Compound 3, half-maximal inhibitory concentration: 207000 nM
The estimate for compound 3 lay 2.1-fold (0.32 log units) below the measured number; measured number outside the range, above it.
By their numbers in this assay, from the lowest: compounds 2, 1 and 3 (each within the scatter of the next, the first and the last beyond it).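

In this assay, methyl in place of hydrogen on the oxygen on the aromatic ring gives a 2.4-fold higher number from compound 2 to compound 3 (0.38 log units; beyond the scatter), a modest step and the first in this series to pass beyond the scatter. Methoxy in place of hydrogen on the aromatic carbon gives a 1.5-fold higher number from compound 1 to compound 3 (0.19 log units; within the scatter), so the methoxy cannot be told apart from the hydrogen, and the hydroxy of compound 2 differs beyond the scatter only from the methoxy. Nothing available accounts for the effect of this methyl.

The compounds shown leave open whether a longer chain such as ethyl on this oxygen, or an amine or fluorine in place of the hydroxy, would move the number further. They also leave open whether methyl on the oxygen of the 4-hydroxy group would give a similar step.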